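This account rests on a few compounds, and the source may have more. Where it says the series, first, only, none or still open, it means among the compounds named here.

Three compounds share one core and differ only in the aromatic group attached to it. In a functional assay on BJAB cells (Homo sapiens) for antiproliferative activity, with a stated time of 4 days (a lower number here means that less compound is needed, a higher number that more compound is needed for the effect), compound 1 `Cc1nn(-c2nc(-c3ccc(Cl)c(Cl)c3)c(SC(C)C)s2)c(C(=O)O)c1-c1cncc(C#N)c1` gives 20000 nM. Compound 2 `Cc1nn(-c2nc(-c3ccc(Cl)c(Cl)c3)c(SC(C)C)s2)c(C(=O)O)c1-c1ccccc1Cl` gives 13100 nM in this assay, and compound 3 `COc1ccc(C)cc1-c1c(C)nn(-c2nc(-c3ccc(Cl)c(Cl)c3)c(SC(C)C)s2)c1C(=O)O` gives 9500 nM in this assay. Compound 3 has the lowest number of the three, but only its gap to compound 1 is beyond the scatter, while it sits within the scatter of compound 2. Compound 4 `Cc1nn(-c2nc(-c3ccc(Cl)c(Cl)c3)c(SC(C)C)s2)c(C(=O)O)c1-c1ccccc1` carries the simplest group of the set at that position: phenyl in place of 2-methoxy-5-methylphenyl on an aromatic carbon. The measured steps that bear on this change are the three exchanges of one aromatic group for another at the same position: a 1.5-fold lower number from compound 1 to compound 2 (0.18 log units; within the scatter), a 2.1-fold lower number from compound 1 to compound 3 (0.32 log units; beyond the scatter) and a 1.4-fold lower number from compound 2 to compound 3 (0.14 log units; within the scatter). All of them were small, and only the largest just cleared the scatter, so a similarly small step is expected here, with no clear direction: a 1.3-fold higher number from compound 3 to compound 4 (0.10 log units; within the scatter). Compound 4 is therefore estimated to give 12000 nM in this assay, most likely between 5000 nM and 30000 nM.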

Compound 4, half-maximal effective concentration: 3000 nM
Estimate against measurement, compound 4: 4.0-fold (0.60 log units) above, and the stated range ends above it.
By their numbers in this assay, from the lowest: compound 4; then compounds 3, 2 and 1 (each within the scatter of the next, the first and the last beyond it).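

In this assay, the plain phenyl of compound 4 gives the lowest number of the set, with a 3.2-fold lower number from compound 3 to compound 4 (0.50 log units; beyond the scatter), a 4.4-fold lower number from compound 2 to compound 4 (0.64 log units; beyond the scatter) and a 6.7-fold lower number from compound 1 to compound 4 (0.82 log units; beyond the scatter), all beyond the scatter. This position therefore responds more strongly than the small steps among the first three compounds suggested: each of those three carries a substituted aromatic group, and each gives a higher number than the unsubstituted phenyl. Nothing available explains why removing these substituents goes with a lower number.

Compound 3 carries both a methoxy and a methyl group, so the compounds shown cannot separate what each contributes. On these data alone, it also remains open whether a single small group on the phenyl, such as fluoro, or a cyclohexyl group in its place would keep the number this low.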